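The compounds below may be only part of what the source reports. "The series", "measured", "known", "first", "only" and "open" are said of these compounds alone.

Of the compounds shown here, three built on one shared core have been measured in an assay on HEK293 cells for displacement of a labelled ligand from NPC1-like intracellular cholesterol transporter 1 (Homo sapiens); on this read-out lower numbers stand for stronger inhibition and higher numbers for weaker inhibition. Compound 1 `CCOC(=O)C1CCN(C(=O)CN2CN(c3ccccc3)C3(CCN(C(=O)c4ccc(C5CCCCC5)cc4)CC3)C2=O)CC1` gives 900 nM. Compound 2 `COC(=O)CCCNC(=O)CN1CN(c2ccccc2)C2(CCN(C(=O)c3ccc(C4CCCCC4)cc3)CC2)C1=O` gives 2500 nM, and compound 3 `NC(=O)C1CCCN(C(=O)CN2CN(c3ccccc3)C3(CCN(C(=O)c4ccc(C5CCCCC5)cc4)CC3)C2=O)C1` gives 3100 nM. Compound 3 thus shows the highest of the three numbers; its nearest neighbour is compound 2, which sits within the scatter, and the furthest is compound 1, whose number is lower by a 3.4-fold higher number from compound 1 to compound 3 (0.54 log units; beyond the scatter).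

Compound 4 `COC(=O)CCNC(=O)CN1CN(c2ccccc2)C2(CCN(C(=O)c3ccc(C4CCCCC4)cc3)CC2)C1=O` differs from compound 3 in one place: (2-(methoxycarbonyl)ethyl)amino in place of 3-carbamoylpiperidin-1-yl on a carbonyl carbon. Among the measured steps, the one from compound 2 to compound 3, a 1.2-fold higher number from compound 2 to compound 3 (0.09 log units; within the scatter), bears most closely on this change, since compound 2 carries an open-chain ester-bearing amino group of the same kind as compound 4, differing only in chain length. The steps of a 2.8-fold higher number from compound 1 to compound 2 (0.44 log units; beyond the scatter) and a 3.4-fold higher number from compound 1 to compound 3 (0.54 log units; beyond the scatter) show that both the open-chain amino ester and the carbamoylpiperidine give modestly higher numbers than the ethoxycarbonylpiperidine of compound 1.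

On this basis compound 4 is expected to land close to compound 3, with a step of a 1.2-fold lower number from compound 3 to compound 4 (0.09 log units; within the scatter) that is not expected to exceed the scatter. The estimate for compound 4 in this assay is 2500 nM, within a range of 1200 nM to 6000 nM.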

Compound 4, half-maximal inhibitory concentration: 12900 nM
Estimate against measurement, compound 4: 5.2-fold (0.71 log units) below; measured number outside the range, above it.
By their numbers in this assay, from the lowest: compound 1; then compounds 2 and 3 (each within the scatter of the next); then compound 4.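

In this assay, the step of a 5.2-fold higher number from compound 2 to compound 4 (0.71 log units; beyond the scatter) shows that the length of the ester-bearing chain on this carbonyl carbon matters: replacing the (methoxycarbonyl)methyl group on the chain with methoxycarbonyl, which turns the (3-(methoxycarbonyl)propyl)amino group into (2-(methoxycarbonyl)ethyl)amino, gives a clearly higher number. For the compounds shown here, open-chain esters therefore do not behave as a single group here, for the step of a 4.2-fold higher number from compound 3 to compound 4 (0.62 log units; beyond the scatter) sets the shorter ester chain apart from the 3-carbamoylpiperidin-1-yl group, whereas the longer one could not be told apart from it, and the step of a 14-fold higher number from compound 1 to compound 4 (1.16 log units; beyond the scatter) is the first large change seen at this position. The compounds shown offer no independent data that could explain why this shortening raises the number.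

On these data alone, it remains open whether a longer chain than that of compound 2 would bring the number closer to that of compound 1, or whether the trend with chain length would continue at all. As far as these compounds go, it is also open whether the ester itself matters on these chains, which a carboxylic acid or a primary amide at the chain end would test.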